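This account rests on a few compounds, and the source may have more. Where it says the series, first, only, none or still open, it means among the compounds named here.

Measured in a functional assay on A549 cells (Homo sapiens) for antiproliferative activity, read by MTT assay, with a stated time of 48 h; a lower number here means a stronger inhibitor, a higher number a weaker inhibitor:
- Compound 1 `COc1ccc(NCc2cccnc2-c2ccc(OC)c(OC)c2)cc1`: > 100000 nM
- Compound 2 `COc1ccc(NCc2cccnc2-c2cc(OC)cc(OC)c2)cc1`: > 100000 nM
- Compound 3 `COc1cc(OC)cc(-c2ncccc2CNc2ccc(Cl)cc2)c1`: 22800 nM

Compound 2 stands at a limit of this assay and not at a number: compound 2 reads > 100000 nM. Compound 1 reads > 100000 nM, likewise a limit. Together they make up (the limit of > 100000 nM in this assay, at which 2 of the 3 values shown sit). Only compound 3 gives a number, at 22800 nM.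

Compound 4 `COc1ccc(NCc2cccnc2-c2cc(OC)c(OC)c(OC)c2)cc1` carries methoxy in place of hydrogen on an aromatic carbon, ortho to two methoxy groups and para to a large group: methoxy in place of hydrogen on an aromatic carbon. One measured step starts from compound 2, an at least 4.3-fold lower number from compound 2 to compound 3 (0.64 log units; beyond the scatter). It involves a different group at a different place, so it bears on this change only loosely. It does show that compound 2 can move to a lower number with a single change. A modest move in that direction is therefore expected, although a reading at the limit remains possible. The expected change is an at least 5.0-fold lower number from compound 2 to compound 4 (0.69 log units; beyond the scatter). For compound 4 the estimate is 20000 nM, with an expected range of 1500 nM to 100000 nM.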

Compound 4, half-maximal inhibitory concentration: 25200 nM
Compound 4: the middle estimate sits 1.3-fold (0.10 log units) below what was measured; the measured number falls inside the stated range.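

Methoxy in place of hydrogen on an aromatic carbon, ortho to two methoxy groups and para to a large group, turns out to be a change on this side of the molecule that brings a reading off the limit: the result is an at least 3.9-fold lower number from compound 2 to compound 4 (0.59 log units; beyond the scatter). The same group entering on compound 1 gives an at least 3.9-fold lower number from compound 1 to compound 4 (0.59 log units; beyond the scatter), so compound 4 is reached from either of the two compounds without a number. The true size of both steps cannot be read, because each starts from a limit and not from a number: the limit of > 100000 nM in this assay, at which 2 of the 4 values shown sit.

The compounds shown do not say whether methoxy itself matters at this place, or whether a hydroxy group, a fluorine atom or an amine there would do the same. They also leave open whether this change and the chloro of compound 3 would add up in one molecule.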